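Methyl to bromo on the shared core: notes for compound 3

The source may hold more compounds than are shown below. What is called first, only, known or untested is meant among the compounds shown, and "the series" means these compounds.

The series is read in an assay for binding affinity to Indoleamine 2,3-dioxygenase 1 variant C129Y (Homo sapiens), read by spectrophotometry, with a stated time of 30 min; on this read-out higher numbers stand for weaker binding and lower numbers for tighter binding. Compound 1 `OC(Cc1ccccc1)c1cccc2[nH]ncc12` gives 66000 nM. Compound 2 `Cc1cc(C(O)Cc2ccccc2)c2cn[nH]c2c1` gives 27000 nM. Going by the values given here, the single measured step is a 2.4-fold lower number from compound 1 to compound 2 (0.39 log units; beyond the scatter), so compound 2 holds the lowest number of the two measured compounds, with compound 1 as its nearest neighbour. Compound 3 `OC(Cc1ccccc1)c1cc(Br)cc2[nH]ncc12` differs from compound 2 by bromo in place of methyl on an aromatic carbon. Among the compounds with values here, no measured step exchanges methyl for bromo; the only step touching this carbon is a 2.4-fold lower number from compound 1 to compound 2 (0.39 log units; beyond the scatter), which moved the number modestly when methyl replaced hydrogen. Whether bromo keeps that gain is not shown. The step from compound 2 to compound 3 in this assay is therefore expected to be small, a 1.2-fold lower number from compound 2 to compound 3 (0.09 log units; within the scatter), and not clearly beyond the scatter in either direction. For compound 3 the expected value is 22000 nM, with a range from 8000 nM to 60000 nM.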

Compound 3, dissociation constant: 2200 nM
Beside the measured number, compound 3's estimate is 10-fold (1.00 log units) above it, outside the stated range (below it).
By their numbers in this assay, from the lowest: compound 3; then compound 2; then compound 1.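

In this assay, the number at this aromatic carbon depends strongly on which group sits there: the step is a 30-fold lower number from compound 1 to compound 3 (1.48 log units; beyond the scatter) for bromo in place of hydrogen, whereas methyl in place of hydrogen gave only a 2.4-fold lower number from compound 1 to compound 2 (0.39 log units; beyond the scatter) in the earlier data. Exchanging methyl for bromo alone gives a 12-fold lower number from compound 2 to compound 3 (1.09 log units; beyond the scatter), so these two groups, each of one heavy atom with no hydrogen-bond donor or acceptor and no net charge, are far from interchangeable at this carbon. Nothing at hand accounts for the difference between them.

The compounds shown leave open how chloro, iodo, methoxy or a nitrile would read at this carbon. They also leave open whether the gain from bromo carries over when the hydroxyl or the phenyl of the shared core is changed.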